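A few compounds are considered here, and "the series" means these few. Any claim that something is new, unique, unknown or untested is made for them only; others in the source may bear on it.

Compound 1 `Cc1nc(Nc2ccc(Cl)cc2)sc1C(=O)/C=C/c1ccccc1` gives in a functional assay on Bel-7402 cells (Homo sapiens) for cytotoxicity, read by MTT assay (a higher number here means a weaker inhibitor, a lower number a stronger inhibitor), a limit of > 25000 nM.
Compound 2 `Cc1cccc(Nc2nc(C)c(C(=O)/C=C/c3ccccc3)s2)c1` gives in this assay a limit of > 25000 nM.
Compound 3 `Cc1nc(Nc2ccccc2)sc1C(=O)/C=C/c1ccccc1` gives in this assay a limit of > 25000 nM.

Compound 3 therefore stands nowhere that a number could place it: its value is a limit, and the values of its two neighbours are limits as well, so no one of the three can be set above or below another. The step to compound 4 `Cc1ccc(Nc2nc(C)c(C(=O)/C=C/c3ccccc3)s2)cc1` is methyl in place of hydrogen on an aromatic carbon — methyl in place of hydrogen on an aromatic carbon of a six-membered aromatic ring of carbon only, para to a large group, so that the anilino becomes a (4-methylphenyl)amino.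

Among the measured compounds shown here, three measured steps bear on this change, each altering the same aryl group on the nitrogen: a step that the two limits leave unreadable from compound 1 to compound 2, a step that the two limits leave unreadable from compound 1 to compound 3 and a step that the two limits leave unreadable from compound 2 to compound 3. None of them can be read, because the limit of > 25000 nM in this assay, at which 3 of the 3 values shown sit, holds every value that has been obtained. Nothing here shows a substituent on that ring moving the read-out into the measurable range, and a methyl is no more than the chloro or methyl already tried.

Compound 4 is accordingly expected to remain at the limit, with an estimated value of 40000 nM, between 15000 nM and 200000 nM, meaning an expected step that the limit leaves unreadable from compound 3 to compound 4.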

Compound 4, half-maximal inhibitory concentration: > 25000 nM
Compound 4 ended at the assay's limit (the forecaster's own chance of this, stated with the estimate: 85%); the middle value lies beyond the limit too.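

In this assay compound 4 gives > 25000 nM as a limit and not a number. None of the new steps joining compound 4 to compound 1, compound 2 and compound 3 can be read: the limit of > 25000 nM in this assay, at which 4 of the 4 values shown sit.
The compounds shown leave open how far beyond the limit each lies, and whether any change to the shared core reaches the measurable range.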